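The source may hold more compounds than are shown below. What is called first, only, known or untested is meant among the compounds shown, and "the series" means these compounds.

Compound 1 `CC1(C)COC(=O)N1C1CCN(C(=O)c2nc3c(C(F)(F)F)cc(-c4ccoc4)cn3c2Cl)CC1`: > 500000 nM
Compound 2 `O=C(c1nc2c(C(F)(F)F)cc(-c3ccoc3)cn2c1Cl)N1CCN(C2CCCCC2)C(=O)C1`: > 500000 nM

In a physicochemical assay for solubility (a higher number here means a more soluble compound, a lower number a less soluble compound), compound 1 gives > 500000 nM, which is a limit and not a number. Compound 2 gives > 500000 nM, which is also a limit. Compound 2 therefore has no exact value and stands with compound 1 at the limit of > 500000 nM in this assay, at which 2 of the 2 values shown sit.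

Compound 3 `O=C(c1nc2c(C(F)(F)F)cc(-c3ccoc3)cn2c1Cl)N1CCN([C@H]2CC[C@H](O)CC2)C(=O)C1` differs from compound 2 in one place: hydroxy in place of hydrogen on a saturated ring carbon. Hydroxy takes the place of hydrogen on a saturated ring carbon, turning cyclohexyl into 4-hydroxycyclohexyl. For the measured compounds named here, no measured pair of compounds shows the size of such a change. With compound 2 reading > 500000 nM, no step beyond the scatter can be expected to show in this assay, and another limit is the likeliest result. The expected change is a number no higher from compound 2 to compound 3 (the limit leaves the size open). For compound 3, the estimated value is 500000 nM, with an expected range of 250000 nM to 1000000 nM.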

Compound 3, solubility: > 500000 nM
Compound 3 ended at the assay's limit (the forecaster's own chance of this, stated with the estimate: 75%); the middle value sits exactly at the limit.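

Compound 2 and compound 3 both end at a limit in this assay, so no size can be read for the change from cyclohexyl to 4-hydroxycyclohexyl: the limit of > 500000 nM in this assay, at which 3 of the 3 values shown sit. The compounds shown leave open how far past that limit the true solubility of each one lies.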